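The source may report more compounds than this note shows. Statements on the series, on what has been measured and on what is new or still open speak of the compounds shown alone.

Working notes on the series, cytotoxicity in an ADME assay on NIH3T3 cells (Mus musculus) for cytotoxicity, read by CCK-8 assay, with a stated time of 24 h; on this read-out higher numbers stand for weaker inhibition and lower numbers for stronger inhibition.

Compound 1 `C/C(=C\c1nc(-c2ccccc2)cs1)C(N)=O` is the unsubstituted member of the first pair. Compound 2 `C/C(=C\c1nc(-c2ccc(C)cc2)cs1)C(N)=O` is its counterpart carrying the change (methyl in place of hydrogen on an aromatic carbon). Compound 3 `C/C(=C\c1cccc(-c2ccccc2)c1)C(N)=O` belongs to a second pair with a different core; the difference between the two cores is not broken down here. Compound 4 `C/C(=C\c1cccc(-c2ccc(C)cc2)c1)C(N)=O`, not yet measured, is obtained from compound 3 by the same change, (methyl in place of hydrogen on an aromatic carbon), at a place described in the same words as for the first pair.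

In this assay compound 1 gives only a limit, > 50000 nM. Compound 2 likewise gives only a limit in this assay, > 50000 nM. Compound 3 also returns a limit in this assay, > 50000 nM. Among the compounds with values here, the measured step that the two limits leave unreadable from compound 1 to compound 2 therefore has no readable size, because the limit of > 50000 nM in this assay, at which 3 of the 3 values shown sit, is where every value of the three compounds sits; nothing in the data separates the methyl-bearing compound from its parent on this read-out, and no compound is weaker or stronger than another within the scatter.

For the second pair the step from compound 3 to compound 4 is expected to be a step that the limit leaves unreadable from compound 3 to compound 4, resting on the unreadable step that the two limits leave unreadable from compound 1 to compound 2 for the matching change and on the limit that compound 3 gives, > 50000 nM. On that basis compound 4 is estimated at 60000 nM, with a plausible span from 30000 nM to 150000 nM, and most likely it will again be reported only as a limit.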

Compound 4, half-maximal inhibitory concentration: > 50000 nM
Compound 4: only a limit was reported (the forecaster's own chance of this, stated with the estimate: 85%); the middle value is on the limit's open side.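

Compound 4 gives only a limit in this assay, > 50000 nM. No size can be read for the methyl step from compound 3 to compound 4 or from compound 1 to compound 2, because all four compounds sit at the same limit: the limit of > 50000 nM in this assay, at which 4 of the 4 values shown sit.

The compounds shown leave open whether methyl in place of hydrogen changes cytotoxicity on either core, and at what concentration any of the four compounds would inhibit.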